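This account rests on a few compounds, and the source may have more. Where it says the series, first, only, none or still open, it means among the compounds named here.

Working notes on the series. Compound 1 `COc1cc(/C=C/C(=O)c2cccc(O)c2)ccc1O` gives 94% in an ADME assay on RAW264.7 cells (Mus musculus) for cytotoxicity, read by MTT assay, with a stated time of 24 h, tested at 2.5 ug/mL; a higher number here means a weaker effect of the compound at the concentration tested, a lower number a stronger effect. Compound 3 `COc1ccc(/C=C/C(=O)c2cccc(O)c2)cc1OC` gives 91% in this assay. The change from compound 3 to compound 1 is hydrogen in place of methyl on an oxygen on an aromatic ring, and the step is a number 3 percentage points higher from compound 3 to compound 1 (within the scatter). Compound 2 `COc1ccc(/C=C/C(=O)c2ccc(OC)c(OC)c2)cc1` gives 93.1% in this assay; how the core of compound 2 differs from that of compound 3 is not broken down here, so only their two values stand side by side. Compound 4 `COc1ccc(/C=C/C(=O)c2ccc(O)c(OC)c2)cc1` awaits measurement in this assay and differs from compound 2 by hydrogen in place of methyl on an oxygen on an aromatic ring, the same change as from compound 3 to compound 1, with the same surroundings at the place. Since the earlier step was a number 3 percentage points higher from compound 3 to compound 1 (within the scatter), the step from compound 2 to compound 4 is expected to be a number 1.4 percentage points higher from compound 2 to compound 4 (within the scatter), resting on that single precedent and the flat values of all three compounds. Compound 4 is therefore estimated at 94.5%, between 88% and 100%.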

Compound 4, a percentage reported as activity, at one concentration (the size of the read-out at that concentration, not a potency): 96%
Compound 4: the middle estimate sits 1.5 percentage points below what was measured, and the stated range covers the measured number.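

In this assay hydrogen in place of methyl on an oxygen on an aromatic ring gives a number 2.9 percentage points higher from compound 2 to compound 4 (within the scatter) and sits beside its precedent on the other core: the same change on two cores in this assay, a number 3 percentage points higher (within the scatter) from compound 3 to compound 1 and a number 2.9 percentage points higher (within the scatter) from compound 2 to compound 4, 0.1 percentage points apart, within the scatter of two such steps. On these two cores, the change therefore carries over with a step of the same size. Since both steps lie within the scatter, this shows only that the read-out stays flat across the change at the one concentration tested, not that the change has a real effect of transferable size or that the agreement extends to other cores.

The compounds shown leave open what a longer chain on that oxygen would give. They also leave open whether an amine or a carboxylic acid in place of the methoxy would give a step beyond the scatter.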